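Limit readings so far on the series

A few compounds are considered here, and "the series" means these few. Any claim that something is new, unique, unknown or untested is made for them only; others in the source may bear on it.

Compound 1 `Cn1nc(C(F)(F)F)cc1C(=O)Nc1ccc(S(=O)(=O)N2CCCCC2)cc1` gives > 75000 nM as a limit
Compound 2 `Cn1nc(C(F)(F)F)cc1C(=O)Nc1ccc(S(=O)(=O)c2ccccc2CO)cc1` gives > 75000 nM as a limit
Compound 3 `Cn1nc(C(F)(F)F)cc1C(=O)Nc1ccc(S(=O)(=O)c2ccccc2O)cc1` awaits measurement

In an ADME assay on Vero cells (Chlorocebus sabaeus) for cytotoxicity, read by MTT assay, with a stated time of 24 h (on this read-out lower numbers stand for higher toxicity in this test and higher numbers for lower toxicity in this test), compound 2 stands at > 75000 nM as a limit and not a number. Both measured compounds share that reading (the limit of > 75000 nM in this assay, at which 2 of the 2 values shown sit). Compound 3 carries one change (hydroxy in place of hydroxymethyl on an aromatic carbon), hydroxy in place of hydroxymethyl on an aromatic carbon. For the measured compounds named here, the only measured step (a step that the two limits leave unreadable from compound 1 to compound 2) has no readable size. Going by the values given here, with only that step to go on, no step beyond the scatter is expected in this assay for this change, and another limit is likely. The estimated step (an at least 1.0-fold lower number from compound 2 to compound 3 (0.02 log units; that floor lies within the scatter)) fits that expectation. The estimate for compound 3 is 70000 nM with an expected range from 25000 nM to 150000 nM as its upper end.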

Compound 3, half-maximal cytotoxic concentration: 75000 nM
Estimate against measurement, compound 3: 1.1-fold (0.03 log units) below, within the range that was stated.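

In this assay, for the compounds shown here, compound 3 gives 75000 nM, the only reading that is a number and not a limit. The data show a number no higher from compound 2 to compound 3 (the limit leaves the size open) and a number no higher from compound 1 to compound 3 (the limit leaves the size open) and neither step can be read, and hydroxy in place of hydroxymethyl on this aromatic carbon therefore has no size to report. The number stands at the same figure as the limit of the other two compounds: the limit of > 75000 nM in this assay, at which 2 of the 3 values shown sit.

As far as these compounds go, what an amine or a carboxylic acid on this aromatic carbon would do in this assay stays open. Also open, from the compounds shown here alone, is whether any change to the shared core gives a clearly lower number.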